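Shifting the methylene-linked azole on a furan carboxamide series

The source may report more compounds than this note shows. Statements on the series, on what has been measured and on what is new or still open speak of the compounds shown alone.

Measured so far:
Compound 1, `CCn1ncc(NC(=O)c2ccc(Cn3nc(C)cc3C)o2)c1C(N)=O`: > 100000 nM
Compound 2, `CCn1cc(NC(=O)c2ccc(Cn3nc(C)cc3C)o2)c(C(=O)NC)n1`: 18100 nM
Compound 3, `CCn1cc(NC(=O)c2ccc(Cn3cccn3)o2)c(C(N)=O)n1`: 75100 nM

Three compounds have been examined in a functional assay on HT-1080 cells (Homo sapiens) for inhibition, read by WST assay and cell counting, with a stated time of 72 h; on this read-out higher numbers stand for weaker inhibition and lower numbers for stronger inhibition. For compound 1 the result is a limit of the assay rather than a number: compound 1 reaches only (the limit of > 100000 nM in this assay, at which 1 of the 3 values shown sits). Of the two compounds that give a number, compound 3 stands at the higher one with 75100 nM, while compound 2 gives the lower one with 18100 nM, a gap that lies beyond the usual scatter. Compound 3 therefore stands as the weaker of the two measured inhibitors, with compound 1 giving only a limit in this assay.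

The next compound, compound 4, `CCn1cc(NC(=O)c2ccc(Cc3c(C)noc3C)o2)c(C(N)=O)n1`, differs from compound 3 in a single place: 3,5-dimethyl-1,2-oxazol-4-yl in place of 1H-pyrazol-1-yl on a saturated chain carbon bound to an aromatic carbon. For the measured compounds named here, no measured pair in this small set isolates that change, so the direction of the step cannot be read from an earlier example. Compound 4 is therefore expected to land near compound 3, with a step from compound 3 to compound 4 of a 1.5-fold lower number from compound 3 to compound 4 (0.18 log units; within the scatter) that is small and uncertain in sign. The estimate for compound 4 in this assay is 50000 nM, with a range from 15000 nM to 150000 nM.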

Compound 4, half-maximal inhibitory concentration: > 100000 nM
Compound 4: a limit, no number (the forecaster's own chance of this, stated with the estimate: 25%); at least 2.0-fold (0.30 log units) between middle value and limit.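

In this assay, for the compounds shown here, replacing (1H-pyrazol-1-yl)methyl with (3,5-dimethyl-1,2-oxazol-4-yl)methyl is the first change in the set that can be read at a single place, and it gives an at least 1.3-fold higher number from compound 3 to compound 4 (0.12 log units; that floor lies within the scatter). As far as these compounds go, this shows that, on the saturated chain carbon bound to an aromatic carbon, the larger 3,5-dimethyl-1,2-oxazol-4-yl group brings no measurable gain in inhibition over the 1H-pyrazol-1-yl group, although the floor of the step does not establish a real loss and its true size remains unknown. Compound 4 gives only a limit of the assay and not a number: the limit of > 100000 nM in this assay, at which 2 of the 4 values shown sit.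

The compounds shown leave open whether the two methyl groups or the change of ring from 1H-pyrazol-1-yl to 3,5-dimethyl-1,2-oxazol-4-yl accounts for the step, since both differ together between compound 3 and compound 4. They also leave open whether an amine such as morpholine, or a carboxylic acid, on that same chain carbon would give a lower number than compound 3 does.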